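Isopropyl thioether replaces a 2-methylbenzyl group

A few compounds are considered here, and "the series" means these few. Any claim that something is new, unique, unknown or untested is made for them only; others in the source may bear on it.

Compound 1, `Cc1ccccc1CSc1n[nH]c(-n2[se]c3ccccc3c2=O)n1`: 36200 nM
Compound 2, `CCCCCCSc1n[nH]c(-n2[se]c3ccccc3c2=O)n1`: 22400 nM
Compound 3, `O=c1c2ccccc2[se]n1-c1nc(SCc2ccc([N+](=O)[O-])cc2)n[nH]1`: 8910 nM

Three compounds share one core and differ only in the group carried on the sulfur. In a functional assay on SMMC-7721 cells (Homo sapiens) for antiproliferative activity, read by CCK-8 assay, with a stated time of 48 h (a lower number here means a stronger inhibitor, a higher number a weaker inhibitor), compound 1 gives 36200 nM, the highest of the three numbers. Its nearest neighbour is compound 2, and the step of a 1.6-fold lower number from compound 1 to compound 2 (0.21 log units; within the scatter) is within the scatter, so the two cannot be ordered. Compound 3, with 8910 nM, lies beyond the scatter from compound 1.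

The next compound, compound 4, `CC(C)Sc1n[nH]c(-n2[se]c3ccccc3c2=O)n1`, has not yet been measured. Its change from compound 1 is isopropyl in place of 2-methylbenzyl on a sulfur. Among the compounds with values here, the only measured step that bears on it is the one from compound 1 to compound 2, where a saturated chain replaced the aromatic group and the number moved by a 1.6-fold lower number from compound 1 to compound 2 (0.21 log units; within the scatter), a shift within the scatter. Isopropyl is a shorter branched chain than the group entering in that step, and nothing measured separates chain length or branching. On this basis the step to compound 4 is expected to be small, at most a modest move to a lower number, and it may well stay within the scatter.

Compound 4 is therefore estimated to give 26000 nM in this assay, with a range from 11000 nM to 60000 nM, a change of a 1.4-fold lower number from compound 1 to compound 4 (0.14 log units; within the scatter) that is expected rather than known.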

Compound 4, half-maximal inhibitory concentration: 6010 nM
Estimate against measurement, compound 4: 4.3-fold (0.64 log units) above, outside the stated range (below it).
By their numbers in this assay, from the lowest: compounds 4 and 3 (each within the scatter of the next); then compounds 2 and 1 (each within the scatter of the next).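

In this assay the step of a 6.0-fold lower number from compound 1 to compound 4 (0.78 log units; beyond the scatter) and the step of a 3.7-fold lower number from compound 2 to compound 4 (0.57 log units; beyond the scatter) show that the group on the sulfur can move the number beyond the scatter, which the earlier step from the 2-methylbenzyl compound to the hexyl compound did not show. Replacing the aromatic group with a saturated chain is therefore not enough on its own: compound 2, with hexyl, cannot be ordered against compound 1, whereas compound 4, with isopropyl, stands apart from both, so the identity of the chain matters at this place. A smaller group does not account for the whole set, however, and compound 3 goes against such a reading, for with its larger nitrobenzyl group compound 3 gives 8910 nM and stays within the scatter of compound 4.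

No other measurement bears on why isopropyl differs from the other groups. On these data alone, whether branching or chain length is what counts stays open, and a straight propyl chain, a tert-butyl group, a cyclopropyl ring or a chain ending in an amine or a carboxylic acid on the sulfur would bear on that question.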